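The source may report more compounds than this note shows. Statements on the series, on what has been measured and on what is new or still open speak of the compounds shown alone.

Measured compounds:
compound 1 `CC(C(=O)NCc1ccc(C(F)(F)F)nc1NC1CCCCC1)c1ccc(NS(C)(=O)=O)c(F)c1` — 260 nM
compound 2 `CC(C(=O)NCc1ccc(C(F)(F)F)nc1Nc1ccccc1)c1ccc(NS(C)(=O)=O)c(F)c1` — 1400 nM

In a functional assay on CHO-K1 cells for antagonist activity at transient receptor potential cation channel subfamily V member 1 (Homo sapiens), read by FLIPR (a lower number here means a stronger inhibitor, a higher number a weaker inhibitor), compound 2 stands highest of the two numbers; its nearest neighbour is compound 1, and the step of a 5.4-fold higher number from compound 1 to compound 2 (0.73 log units; beyond the scatter) lies beyond the scatter. Compound 3 `CCCCOC1CCN(c2nc(C(F)(F)F)ccc2CNC(=O)C(C)c2ccc(NS(C)(=O)=O)c(F)c2)CC1` differs from compound 2 in one place: a group of 11 heavy atoms (9 carbon, 1 nitrogen, 1 oxygen; one six-membered non-aromatic ring with 1 hetero atom) in place of a group of 7 heavy atoms (6 carbon, 1 nitrogen; one six-membered aromatic ring of carbon only), on an aromatic carbon. Within the data shown here, the only measured step, a 5.4-fold higher number from compound 1 to compound 2 (0.73 log units; beyond the scatter), shows a non-aromatic ring on that carbon giving a lower number than an aromatic one, so a lower number in this assay is expected for compound 3, by about a 2.8-fold lower number from compound 2 to compound 3 (0.45 log units; beyond the scatter). Compound 3 is estimated at 500 nM, within 120 nM to 2500 nM.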

Compound 3, half-maximal inhibitory concentration: 28.2 nM
For compound 3 the middle estimate is 18-fold (1.25 log units) above the measured one; the measured number lies below the stated range.
By their numbers in this assay, from the lowest: compound 3; then compound 1; then compound 2.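

In this assay, replacing the anilino group on this aromatic carbon gives a 50-fold lower number from compound 2 to compound 3 (1.70 log units; beyond the scatter), and replacing the cyclohexyl-bearing group gives a 9.2-fold lower number from compound 1 to compound 3 (0.96 log units; beyond the scatter). A non-aromatic ring alone therefore does not set the level here, since the two non-aromatic groups also differ beyond the scatter, and this position accepts the larger group of 11 heavy atoms. Nothing available explains the gain.

The compounds shown leave open whether the gain follows the ring attached through its nitrogen, the oxygen or the chain beyond it. A methoxy or hydroxyl group in place of that ether chain would begin to separate these.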